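A few compounds are considered here, and "the series" means these few. Any claim that something is new, unique, unknown or untested is made for them only; others in the source may bear on it.

In a functional assay on the whole organism with Mus musculus as the target, at a dose of 50 mg/kg by the intraperitoneal route (on this read-out higher numbers stand for more inhibition at the one dose given (going by the name of the read-out) and lower numbers for less inhibition), compound 3 `O=C(NNc1ccccc1)C1CCC(=O)N1S(=O)(=O)c1ccc(Cl)cc1` gives 71.4%, the highest of the three numbers in hand. Compound 1 `Cc1ccc(S(=O)(=O)N2C(=O)CCC2C(=O)NNc2ccccc2)cc1` gives 64.3% and lies nearest to it, while compound 2 `NNC(=O)C1CCC(=O)N1S(=O)(=O)c1ccc(Cl)cc1` gives 61.1% and lies furthest. The step of a number 7.1 percentage points higher from compound 1 to compound 3 (within the scatter) stays within the scatter, whereas the step of a number 10.3 percentage points higher from compound 2 to compound 3 (beyond the scatter) goes beyond it.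

Compound 4 `O=C(NNc1ccccc1)C1CCC(=O)N1S(=O)(=O)c1ccc(Cl)c(Cl)c1` has not yet been measured. It differs from compound 3 by chloro in place of hydrogen on an aromatic carbon. Among the compounds with values here, of the two measured steps, only the one between compound 1 and compound 3 alters a group on that same aromatic ring, and that step remained within the scatter. The step between compound 2 and compound 3 concerns the amine nitrogen and does not bear on this change. For compound 4 the expected step is therefore a number 0.6 percentage points higher from compound 3 to compound 4 (within the scatter), a move not beyond the scatter. The estimate for compound 4 is 72%, with a range from 58% to 84%.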

Compound 4, a percentage reported as inhibition, in the whole organism at one dose (the size of the read-out at that dose, not a potency): 57.7%
Beside the measured number, compound 4's estimate is 14.3 percentage points above it, outside the stated range (below it).
By their numbers in this assay, from the lowest: compounds 4, 2, 1 and 3 (each within the scatter of the next, the first and the last beyond it).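

Adding a second chloro, ortho to the first and meta to the large group, gives the first step on this aromatic ring that lies beyond the scatter, a number 13.7 percentage points lower from compound 3 to compound 4 (beyond the scatter), in this assay. Within the data shown here, the ring is therefore not indifferent to substitution, although the 3,4-dichlorophenyl group still stands close to the 4-methylphenyl group, a number 6.6 percentage points lower from compound 1 to compound 4 (within the scatter), so only the pair with the 4-chlorophenyl group separates. Nothing at hand explains the lower number at this position.

From the compounds shown here alone, whether a methoxy group or an amine on the same aromatic carbon would shift the number in the same way remains open. Going by these compounds, it is also open whether this lower number depends on the chloro already on the ring or would appear without it.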